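The source may report more compounds than this note shows. Statements on the series, on what has been measured and on what is new or still open speak of the compounds shown alone.

Of the compounds shown here, three have so far been measured in a functional assay on A549 cells (Homo sapiens) for cytotoxicity, read by MTT assay, with a stated time of 4 days; on this read-out higher numbers stand for weaker inhibition and lower numbers for stronger inhibition.

Compound 1 `C=C1C[C@]23C[C@@]1(O)CC[C@@H]2c1cccc(C)c1[C@@H]3Cn1cc(-c2ccc(OC)cc2)nn1` gives > 20000 nM, which is a limit of the assay.
Compound 2 `C=C1C[C@]23C[C@@]1(O)CC[C@H]2c1ccc(O)c(C)c1[C@@H]3Cn1cc(-c2ccc(OC)cc2)nn1` gives > 20000 nM, also a limit.
Compound 3 `C=C1C[C@]23C[C@@]1(O)CC[C@@H]2c1cccc(C)c1[C@@H]3Cn1cc(-c2ccc(C)cc2)nn1` gives > 20000 nM, again a limit.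

Compound 3 arises from compound 1 by methyl in place of methoxy on an aromatic carbon. Because all three values sit at the limit of > 20000 nM in this assay, at which 3 of the 3 values shown sit, the step that the two limits leave unreadable from compound 1 to compound 3 cannot be read. The difference between the cores of compound 1 and compound 2 is not broken down here. Compound 4 `C=C1C[C@]23C[C@@]1(O)CC[C@H]2c1ccc(O)c(C)c1[C@@H]3Cn1cc(-c2ccc(C)cc2)nn1` has not yet been measured in this assay; it arises from compound 2 by methyl in place of methoxy on an aromatic carbon, the same change at the same place as that from compound 1 to compound 3. Compound 4 is expected to show a step that the limit leaves unreadable from compound 2 to compound 4 from the limit reached by compound 2, because that value sits at the limit of > 20000 nM in this assay, at which 3 of the 3 values shown sit. The estimate for compound 4 in this assay is 30000 nM, between 12000 nM and 100000 nM, most likely reported again only as a limit.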

Compound 4, half-maximal inhibitory concentration: > 20000 nM
Compound 4: a limit, no number (the forecaster's own chance of this, stated with the estimate: 85%); the middle value lies beyond the limit too.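

Compound 4 gives > 20000 nM and this is a limit. The change from compound 2 to compound 4 therefore yields no readable step: the limit of > 20000 nM in this assay, at which 4 of the 4 values shown sit. Going by these compounds, whether methoxy or methyl makes any difference in this assay stays open.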